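Thiophen-2-yl replaces isopropoxymethyl: expected cytotoxicity of compound 4

The source may report more compounds than this note shows. Statements on the series, on what has been measured and on what is new or still open speak of the compounds shown alone.

Measured in an ADME assay on cells (Homo sapiens) for cytotoxicity, read by polymerase chain reaction, with a stated time of 3 days; on this read-out higher numbers stand for lower toxicity in this test and lower numbers for higher toxicity in this test:
compound 1 `CNc1nc(C)c(-c2nc3ccccc3s2)c(N[C@@H]2C[C@H](CO)[C@@H](O)[C@H]2O)n1`: compound 1 gives > 25000 nM, a limit of the test.
compound 2 `CCCNc1nc(C)c(-c2nc3ccccc3s2)c(N[C@@H]2C[C@H](CO)[C@@H](O)[C@H]2O)n1`: compound 2 gives > 25000 nM, likewise a limit.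
compound 3 `Cc1nc(NCCOC(C)C)nc(N[C@@H]2C[C@H](CO)[C@@H](O)[C@H]2O)c1-c1nc2ccccc2s1`: compound 3 gives 8000 nM.

Among the compounds with values here, compound 3 holds the only real number; the other two sit at the limit of > 25000 nM in this assay, at which 2 of the 3 values shown sit. The steps of an at least 3.1-fold lower number from compound 1 to compound 3 (0.49 log units; beyond the scatter) and an at least 3.1-fold lower number from compound 2 to compound 3 (0.49 log units; beyond the scatter) both show the lower number arriving with isopropoxymethyl, while a step that the two limits leave unreadable from compound 1 to compound 2 stays unreadable. Compound 4 `Cc1nc(NCc2cccs2)nc(N[C@@H]2C[C@H](CO)[C@@H](O)[C@H]2O)c1-c1nc2ccccc2s1` differs from compound 3 by thiophen-2-yl in place of isopropoxymethyl on a saturated chain carbon bound to a nitrogen on an aromatic ring. Within the data shown here, no measured step covers thiophen-2-yl, so only the loss of isopropoxymethyl can be weighed. Compound 4 is therefore expected to give 15000 nM, within 5000 nM to 40000 nM, a step of a 1.9-fold higher number from compound 3 to compound 4 (0.27 log units; within the scatter) that may again reach the limit.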

Compound 4, half-maximal cytotoxic concentration: 6000 nM
Compound 4: the middle estimate sits 2.5-fold (0.40 log units) above what was measured; the range from low to high includes it.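

In this assay, thiophen-2-yl in place of isopropoxymethyl gives a 1.3-fold lower number from compound 3 to compound 4 (0.12 log units; within the scatter), so on a saturated chain carbon bound to a nitrogen on an aromatic ring the two groups cannot be told apart. The lower number is therefore not tied to isopropoxymethyl, since an aromatic ring at this place also gives it, with an at least 4.1-fold lower number from compound 2 to compound 4 (0.61 log units; beyond the scatter) and with an at least 4.1-fold lower number from compound 1 to compound 4 (0.61 log units; beyond the scatter). Both of these steps give only a bound: the limit of > 25000 nM in this assay, at which 2 of the 4 values shown sit.

The compounds shown leave open whether a basic amine or a carboxylic acid at this place would keep the lower number. They also leave open how a longer chain carrying thiophen-2-yl would read.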